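Fluorine-to-chlorine swap on a dinitrophenyl ether oxime series

The source may report more compounds than this note shows. Statements on the series, on what has been measured and on what is new or still open speak of the compounds shown alone.

Compound 1 `O=[N+]([O-])c1cc(C(F)(F)F)cc([N+](=O)[O-])c1Oc1ccccc1/C=N\OCc1ccccc1F` and compound 2 `O=[N+]([O-])c1cc(C(F)(F)F)cc([N+](=O)[O-])c1Oc1ccccc1/C=N/OCc1ccccc1Cl` share one core, and compound 3 `O=[N+]([O-])c1cc(C(F)(F)F)cc([N+](=O)[O-])c1Oc1c(Cl)cc(Cl)cc1/C=N\OCc1ccccc1F` carries a second core; how the two cores differ is not broken down here. In a functional assay on HepG2 cells (Homo sapiens) for antiproliferative activity, read by MTT assay, with a stated time of 48 h (a higher number here means a weaker inhibitor, a lower number a stronger inhibitor), compound 1 gives 680 nM, compound 2 gives 1170 nM, and compound 3 gives 820 nM. From compound 1 to compound 2 the change is a group of 11 heavy atoms (8 carbon, 1 nitrogen, 1 oxygen, 1 chlorine; one six-membered aromatic ring of carbon only) in place of a group of 11 heavy atoms (8 carbon, 1 nitrogen, 1 oxygen, 1 fluorine; one six-membered aromatic ring of carbon only), on an aromatic carbon, and it gave a 1.7-fold higher number from compound 1 to compound 2 (0.24 log units; within the scatter). Compound 4 `O=[N+]([O-])c1cc(C(F)(F)F)cc([N+](=O)[O-])c1Oc1c(Cl)cc(Cl)cc1/C=N/OCc1ccccc1Cl` has not yet been measured. It arises from compound 3 by the same kind of change, (a group of 11 heavy atoms (8 carbon, 1 nitrogen, 1 oxygen, 1 chlorine; one six-membered aromatic ring of carbon only) in place of a group of 11 heavy atoms (8 carbon, 1 nitrogen, 1 oxygen, 1 fluorine; one six-membered aromatic ring of carbon only), on an aromatic carbon), here at a place that is also meta to two chloro groups. Because of a 1.7-fold higher number from compound 1 to compound 2 (0.24 log units; within the scatter), the step is expected to be about as small as that one, a 1.7-fold higher number from compound 3 to compound 4 (0.23 log units; within the scatter). Compound 4 is therefore expected to give about 1400 nM in this assay, with a plausible range from 700 nM to 2800 nM.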

Compound 4, half-maximal inhibitory concentration: 1120 nM
For compound 4 the middle estimate is 1.3-fold (0.10 log units) above the measured one, and the stated range covers the measured number.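

In this assay the swap of the fluorine-bearing group for the chlorine-bearing group on the core of compound 3 gives a 1.4-fold higher number from compound 3 to compound 4 (0.14 log units; within the scatter). Set beside the same swap on the core of compound 1, the step carries over from one core to the other without a detectable difference: the same change on two cores in this assay, a 1.7-fold higher number (0.24 log units; within the scatter) from compound 1 to compound 2 and a 1.4-fold higher number (0.14 log units; within the scatter) from compound 3 to compound 4, 1.3-fold (0.10 log units) apart, within the scatter of two such steps. Within the data shown here, this shows only that the swap stays within the scatter on both cores; it does not show that the swap has a real effect on either core, and two cores do not make a rule for the whole series.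

The compounds shown leave open what a methoxy group, an amine or a carboxylic acid would give in place of the fluoro or chloro group. They also leave open whether the step stays this small on cores with other substituents.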